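Removing the trifluoromethyl from the benzamide of compound 1

The source may hold more compounds than are shown below. What is called first, only, known or untested is meant among the compounds shown, and "the series" means these compounds.

Measured so far:
compound 1 `COc1cc(-c2nn(-c3cccc(NC(=O)c4cccc(C(F)(F)F)c4)c3)cc2-c2ccncc2)ccc1Cl`: 690 nM
compound 2 `O=C(Nc1cccc(-n2cc(-c3ccncc3)c(-c3ccc(Cl)c(O)c3)n2)c1)Nc1cc(C(F)(F)F)cc(C(F)(F)F)c1`: 790 nM

Both numbers come from a functional assay on A498 cells (Homo sapiens) for inhibition, read by sulforhodamine B assay, with a stated time of 48 h; on this read-out higher numbers stand for weaker inhibition and lower numbers for stronger inhibition. In this assay compound 1 gives 690 nM and compound 2 gives 790 nM. Compound 1 stands at the lowest of the two numbers shown, but compound 2 is its nearest neighbour and the gap between them lies within the scatter, so no order between the two can be claimed. Within the data shown here, no pair of measured compounds differs in a single place, so no step size is anchored by the data.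

Compound 3 `COc1cc(-c2nn(-c3cccc(NC(=O)c4ccccc4)c3)cc2-c2ccncc2)ccc1Cl` has not yet been measured in this assay. It differs from compound 1 in one place: hydrogen in place of trifluoromethyl on an aromatic carbon, meta to a large group; cut one bond further out, benzoyl replaces (3-(trifluoromethyl)phenyl)carbonyl. Losing a trifluoromethyl from an amide aryl in a series of this kind is expected to cost some inhibition, a step somewhat beyond the scatter but not large, and the expected step from compound 1 to compound 3 is a 2.2-fold higher number from compound 1 to compound 3 (0.34 log units; beyond the scatter). Compound 3 is therefore estimated at 1500 nM in this assay, with an expected range from 500 nM to 4500 nM.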

Compound 3, half-maximal inhibitory concentration: 360 nM
Compound 3: the middle estimate sits 4.2-fold (0.62 log units) above what was measured; measured number outside the range, below it.
By their numbers in this assay, from the lowest: compounds 3, 1 and 2 (each within the scatter of the next, the first and the last beyond it).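

In this assay, hydrogen in place of trifluoromethyl on this aromatic carbon gives a 1.9-fold lower number from compound 1 to compound 3 (0.28 log units; within the scatter), so inhibition at this level does not depend on the trifluoromethyl, and the plain benzoyl compound 3 serves as well as compound 1 as a reference for the series. Among these compounds, this is the first one-place comparison, and it gives this position a measured anchor that compounds 1 and 2, which differ in more than one place, could not provide. No evidence on any property of these compounds bears on this step, so the data give no account of it.

From the compounds shown here alone, with only hydrogen and trifluoromethyl compared at this position, it remains open whether another group on the same aromatic carbon, such as an amine or a carboxylic acid, would move the number beyond the scatter. It is also open whether the same exchange would give a comparable step in the urea series of compound 2, since no one-place partner of that compound is shown.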